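From Pyrrolidin-1-yl to 4-Methylpiperazin-1-yl on a Thiocarbonyl Carbon

The source may hold more compounds than are shown below. What is called first, only, known or untested is meant among the compounds shown, and "the series" means these compounds.

In a functional assay on PC-3 cells (Homo sapiens) for inhibition, read by MTT assay, with stated times of 18 h and 4 h (on this read-out lower numbers stand for stronger inhibition and higher numbers for weaker inhibition), compound 1 `CCCCCCCCOP(=O)(O)OCCSC(=S)N1CCCC1` gives > 100000 nM, which is a limit of the assay and not a number. For the measured compounds named here, compound 2 `CCCCCCCCCCOP(=O)(O)OCCSC(=S)N1CCCC1` carries ethyl in place of hydrogen on a saturated chain carbon and gives 56100 nM, the only actual number so far in this assay. Going by the values given here, the one measured step is an at least 1.7-fold lower number from compound 1 to compound 2 (0.25 log units; that floor lies within the scatter), and it is bounded by the limit of > 100000 nM in this assay, at which 1 of the 2 values shown sits. Compound 3 `CCCCCCCCCCOP(=O)(O)OCCSC(=S)N1CCN(C)CC1` keeps the chain of compound 2 and has 4-methylpiperazin-1-yl in place of pyrrolidin-1-yl on a thiocarbonyl carbon. Among the compounds with values here, the step in the chain, an at least 1.7-fold lower number from compound 1 to compound 2 (0.25 log units; that floor lies within the scatter), says nothing about this group, and no measured step changes it, so no shift beyond the scatter is expected. The change expected is a 1.1-fold lower number from compound 2 to compound 3 (0.05 log units; within the scatter). Compound 3 is estimated at 50000 nM, with an expected range from 20000 nM to 110000 nM.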

Compound 3, half-maximal inhibitory concentration: 80000 nM
Estimate against measurement, compound 3: 1.6-fold (0.20 log units) below; measured number inside the range.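

In this assay, exchanging pyrrolidin-1-yl for 4-methylpiperazin-1-yl on a thiocarbonyl carbon gives a 1.4-fold higher number from compound 2 to compound 3 (0.15 log units; within the scatter). For the compounds shown here, the earlier compounds differ only in the chain, so this pair gives the first reading of the group at this position: with the chain of compound 2 kept, a six-membered non-aromatic ring with 2 hetero atoms replaces a five-membered one with 1 hetero atom, and the read-out does not move beyond the scatter. Compound 3 gives a number and not a limit, while one value in the set remains a limit: the limit of > 100000 nM in this assay, at which 1 of the 3 values shown sits.

This single pair cannot show whether other groups at this position, such as morpholin-4-yl or a diethylamino group, would behave alike. It also leaves open whether a longer chain would change the number with either ring in place.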